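Saturated bicyclic amine in place of phenyl on the sulfonyl

A few compounds are considered here, and "the series" means these few. Any claim that something is new, unique, unknown or untested is made for them only; others in the source may bear on it.

For the measured compounds named here, compound 1 `CC1(C)Oc2ccc(S(=O)(=O)c3ccccc3)cc2[C@@H](/N=C(\NC#N)Nc2ccc(Cl)cc2)[C@@H]1O` gives 500 nM in a functional assay (aorta) with Rattus norvegicus as the target (on this read-out higher numbers stand for weaker inhibition and lower numbers for stronger inhibition), the lowest of the two numbers known here. Compound 2 `CC1CC(C)CN(S(=O)(=O)c2ccc3c(c2)[C@@H](/N=C(\NC#N)Nc2ccc(Cl)cc2)[C@H](O)C(C)(C)O3)C1` gives 32100 nM, and the step of a 64-fold higher number from compound 1 to compound 2 (1.81 log units; beyond the scatter) is large. Compound 3 `CC1(C)Oc2ccc(S(=O)(=O)N3CCC(Cc4ccccc4)CC3)cc2[C@@H](/N=C(\NC#N)Nc2ccc(Cl)cc2)[C@@H]1O` reaches only a limit of this assay, > 30000 nM. Compound 4 `CC1(C)Oc2ccc(S(=O)(=O)N3CCCC4CCCCC43)cc2[C@@H](/N=C(\NC#N)Nc2ccc(Cl)cc2)[C@@H]1O` differs from compound 1 by a group of 10 heavy atoms (9 carbon, 1 nitrogen; one six-membered non-aromatic ring of carbon only, one six-membered non-aromatic ring with 1 hetero atom) in place of a group of 6 heavy atoms (6 carbon; one six-membered aromatic ring of carbon only), on a sulfonyl sulfur. The change resembles the moves to compound 2 and compound 3, where a saturated nitrogen ring took the place of the phenyl on the sulfonyl sulfur and the number rose sharply or passed the limit. A large rise in this assay is therefore expected for compound 4, namely a 60-fold higher number from compound 1 to compound 4 (1.78 log units; beyond the scatter). Compound 4 is estimated at 30000 nM, with a range from 8000 nM to 100000 nM.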

Compound 4, half-maximal inhibitory concentration: 8800 nM
For compound 4 the middle estimate is 3.4-fold (0.53 log units) above the measured one; measured number inside the range.
By their numbers in this assay, from the lowest: compound 1; then compound 4; then compound 2.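

In this assay, the saturated bicyclic amine on the sulfonyl sulfur shows a large loss against phenyl, with an 18-fold higher number from compound 1 to compound 4 (1.25 log units; beyond the scatter). The saturated groups do not all behave alike, however: the bicyclic amine gives a 3.6-fold lower number from compound 2 to compound 4 (0.56 log units; beyond the scatter), a modest step. Compound 3 stays at a limit of the read-out: the limit of > 30000 nM in this assay, at which 1 of the 4 values shown sits.

From the compounds shown here alone, whether an aromatic ring other than phenyl, such as pyridyl, would hold the number near that of compound 1 remains open. So does the effect of a small open-chain amine such as dimethylamino on the sulfonyl sulfur.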